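The compounds below may be only part of what the source reports. "The series", "measured", "known", "first", "only" and "open" are said of these compounds alone.

Compound 2 `Cc1c(O)ccc2c1[C@H](Cn1cc(-c3ccc(Cl)cc3)nn1)[C@@]13CC(=O)[C@@](C)(CC[C@@H]21)C3` carries a free hydroxy on its aromatic ring and a chlorophenyl-bearing triazole on the shared core. In a functional assay on A549 cells (Homo sapiens) for cytotoxicity, read by MTT assay, with a stated time of 4 days (on this read-out higher numbers stand for weaker inhibition and lower numbers for stronger inhibition), compound 2 gives > 20000 nM, which is a limit of the measurement rather than a number. Compound 1 `Cc1ccc(S(=O)(=O)Oc2ccc3c(c2C)[C@H](Cn2cc(-c4ccccc4)nn2)[C@@]24CC(=O)[C@@](C)(CC[C@@H]32)C4)cc1` shares the same core but bears a ((4-methylphenyl)sulfonyl)oxy group in place of the hydroxy and a plain phenyl on its triazole. In this assay compound 1 gives > 20000 nM, again a limit and not a number. So both measured compounds stand at the limit of > 20000 nM in this assay, at which 2 of the 2 values shown sit, and no comparison between them can be drawn beyond that.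

Compound 3 `Cc1ccc(S(=O)(=O)Oc2ccc3c(c2C)[C@H](Cn2cc(-c4ccc(Cl)cc4)nn2)[C@@]24CC(=O)[C@@](C)(CC[C@@H]32)C4)cc1` has not been measured. It differs from compound 2 by (4-methylphenyl)sulfonyl in place of hydrogen on an oxygen on an aromatic ring, so that it combines the ((4-methylphenyl)sulfonyl)oxy group of compound 1 with the chlorophenyl triazole of compound 2. Since each of those two features is already present in a compound that reached only a limit, the step that the limit leaves unreadable from compound 2 to compound 3 is expected to be none beyond the scatter, most likely ending at another limit. Compound 3 is therefore estimated at 30000 nM, within a range of 15000 nM to 100000 nM.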

Compound 3, half-maximal inhibitory concentration: > 20000 nM
Compound 3 gave a limit, no number; the forecaster's own chance of this, stated with the estimate: 85%; the middle value does not contradict the limit.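

Compound 3 also gives a limit rather than a number, so neither its step from compound 2 nor its step from compound 1 can be read, and all three compounds end alike: the limit of > 20000 nM in this assay, at which 3 of the 3 values shown sit. The compounds shown leave open whether the ((4-methylphenyl)sulfonyl)oxy group or the chloro group changes anything at all in this assay.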